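Homoserine lactone amides: shortening the chain from compound 2

The source may report more compounds than this note shows. Statements on the series, on what has been measured and on what is new or still open speak of the compounds shown alone.

Measured so far:
compound 1 `O=C(CCCc1ccccc1)N[C@H]1CCOC1=O`: > 100000 nM
compound 2 `O=C(CCCc1ccccc1)CC(=O)N[C@H]1CCOC1=O`: > 100000 nM

Compound 1 `O=C(CCCc1ccccc1)N[C@H]1CCOC1=O` is the plain amide on the shared core. In a functional assay on NCI-H630 cells (Homo sapiens) for cytotoxicity, read by sulforhodamine B assay, with a stated time of 5 days (a higher number here means a weaker inhibitor, a lower number a stronger inhibitor), compound 1 gives no number, only a limit, > 100000 nM. Compound 2 `O=C(CCCc1ccccc1)CC(=O)N[C@H]1CCOC1=O` carries a second carbonyl in the chain. In this assay compound 2 also gives only a limit, > 100000 nM. For the measured compounds named here, compound 2 therefore stands on no scale of numbers: both values shown sit at the limit of > 100000 nM in this assay, at which 2 of the 2 values shown sit, and no step between measured compounds can be sized from them.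

Compound 3 `O=C(CCc1ccccc1)CC(=O)N[C@H]1CCOC1=O` differs from compound 2 by phenyl in place of benzyl on a saturated chain carbon, two bonds along the chain from a carbonyl carbon. Going by the values given here, with no step between measured compounds to draw on, and with compound 2 itself at a limit, the step expected in this assay is a number no higher from compound 2 to compound 3 (the limit leaves the size open), that is, none beyond the scatter. Compound 3 is accordingly estimated at 100000 nM, with a range from 30000 nM to 300000 nM, and most probably the assay will again report only a limit rather than a number for compound 3.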

Compound 3, half-maximal inhibitory concentration: > 100000 nM
Compound 3: a limit, no number (the forecaster's own chance of this, stated with the estimate: 85%); the middle value lies on the limit itself.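

In this assay no step can be read from compound 2 to compound 3, because both compounds give a limit and no number: the limit of > 100000 nM in this assay, at which 3 of the 3 values shown sit.

The compounds shown leave open whether any amide on the shared core gives a number in this assay at all, and what phenyl in place of benzyl changes.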